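The source may hold more compounds than are shown below. What is called first, only, known or untested is meant among the compounds shown, and "the series" means these compounds.

This piece follows one change made to a small set of amide-linked compounds and asks what it should do in a toxicity assay on THP-1 cells (Homo sapiens) for inhibition; on this read-out higher numbers stand for lower toxicity in this test and lower numbers for higher toxicity in this test. Compound 1 `Cc1ccccc1-c1cnc(NC(=O)c2ccc(F)cc2)n1C` reaches only a limit of the assay, not a number: in this assay compound 1 gives > 50000 nM. Compound 2 `Cn1c(-c2cccc(Br)c2)cnc1NC(=O)c1ccc(F)cc1` also stops at a limit; in this assay compound 2 gives > 50000 nM. Compound 3 `COc1cccc(-c2cnc(NC(=O)c3ccc(F)cc3)n2C)c1` stands at a limit as well, and in this assay compound 3 gives > 100000 nM. So compound 3 rests not on a number but on a limit, and the two other values shown are limits too, as the limit of > 100000 nM in this assay, at which 1 of the 3 values shown sits, and the limit of > 50000 nM in this assay, at which 2 of the 3 values shown sit, state. The steps among these compounds, a step that the two limits leave unreadable from compound 1 to compound 2, a step that the two limits leave unreadable from compound 1 to compound 3 and a step that the two limits leave unreadable from compound 2 to compound 3, cannot be read in size: each joins two limits.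

Compound 4 `Cn1c(-c2ccc(Br)cc2)cnc1NC(=O)c1ccc(F)cc1` is not yet measured. It differs from compound 3 in one place: 4-bromophenyl in place of 3-methoxyphenyl on an aromatic carbon. The measured steps that bear on this change are the three above, and none has a readable size; every exchange made so far left the value at a limit. No step beyond the scatter is therefore expected, and the estimated step of an at least 1.2-fold lower number from compound 3 to compound 4 (0.09 log units; that floor lies within the scatter) reflects that. Compound 4 is expected to give about 80000 nM, with a range from 40000 nM to 200000 nM, most likely again reported only as a limit.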

Compound 4, half-maximal cytotoxic concentration: 46000 nM
The estimate for compound 4 lay 1.7-fold (0.24 log units) above the measured number; the range from low to high includes it.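

For the compounds shown here, exchanging 3-methoxyphenyl for 4-bromophenyl gives the first step of readable size in this assay, an at least 2.1-fold lower number from compound 3 to compound 4 (0.33 log units; beyond the scatter), so a change at this place on the core can shift the read-out beyond the scatter, towards higher toxicity in this test. The other two new steps say less: 4-bromophenyl in place of 3-bromophenyl gives an at least 1.0-fold lower number from compound 2 to compound 4 (0.03 log units; that floor lies within the scatter), and 4-bromophenyl in place of 2-methylphenyl gives an at least 1.0-fold lower number from compound 1 to compound 4 (0.03 log units; that floor lies within the scatter), so neither floor shows a shift beyond the scatter. The steps among compound 1, compound 2 and compound 3 still cannot be read, and compound 4 alone carries a number rather than a limit: the limit of > 50000 nM in this assay, at which 2 of the 4 values shown sit.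

From the compounds shown here alone, what an amine or a carboxylic acid on the phenyl ring would do in this assay remains open. Going by these compounds, it is also open whether the shift follows the bromo group itself or where it sits on the ring, a question that a 4-methoxyphenyl group at the same place on the core could help to settle.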